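This account rests on a few compounds, and the source may have more. Where it says the series, first, only, none or still open, it means among the compounds named here.

Series notes. Three compounds have numbers in a physicochemical assay for solubility, in phosphate buffer, at pH 7.4 (a lower number here means a less soluble compound, a higher number a more soluble compound), so far: compound 1 `OCC1CCN(c2nccnc2Oc2ccc(Nc3nc4ccccc4s3)cc2)CC1` gives 6000 nM, compound 2 `OCC1CCN(c2nccnc2OC2CN(c3ncc4ccccc4n3)C2)CC1` gives 174000 nM, and compound 3 `N#CC1CCN(c2nccnc2OC2CN(c3ccc4ccccc4n3)C2)CC1` gives 66000 nM. Compound 3 thus stands second highest of the three, nearest to compound 2 and furthest from compound 1.

Compound 4 `Cc1ncccc1-c1nccnc1OC1CN(c2ccc3ccccc3n2)C1` has not been measured. It differs from compound 3 in one place: 2-methylpyridin-3-yl in place of 4-cyanopiperidin-1-yl on an aromatic carbon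

Within the data shown here, no measured pair shows this change. A downward step from compound 3 is expected in this assay, likely beyond the scatter, on the pattern that compound 1, the most aromatic member, gives 6000 nM. The expected step is a 3.3-fold lower number from compound 3 to compound 4 (0.52 log units; beyond the scatter). Compound 4 is estimated at 20000 nM, within 5000 nM to 80000 nM.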

Compound 4, solubility: 253000 nM
The estimate for compound 4 lay 13-fold (1.10 log units) below the measured number; the measured number lies above the stated range.
By their numbers in this assay, from the lowest: compound 1; then compound 3; then compounds 2 and 4 (each within the scatter of the next).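

In this assay, 2-methylpyridin-3-yl in place of 4-cyanopiperidin-1-yl, on an aromatic carbon next to the ring nitrogen, gives a 3.8-fold higher number from compound 3 to compound 4 (0.58 log units; beyond the scatter). At this position, then, an aromatic ring can stand in place of the non-aromatic ring with no drop in the number.

Still open, on these data alone, is how far the methyl group and the pyridine nitrogen each matter, and how a plain phenyl or a morpholine would read at this position. Nothing available accounts for the size or direction of this step.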